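One Shorter Chain, Measured Twice in the Same Cells

The source may hold more compounds than are shown below. What is called first, only, known or untested is meant among the compounds shown, and "the series" means these compounds.

In a functional assay on A549 cells (Homo sapiens) for antiproliferative activity, read by XTT assay, with a stated time of 72 h (on this read-out higher numbers stand for weaker inhibition and lower numbers for stronger inhibition), three compounds have been measured:

compound 1, `C=C(C)CCC[C@]1(C)C2=CCC[C@](C)(C[C@@H](OC(C)=O)C3=CC(=O)OC3O)[C@H]2CC[C@H]1C`, gives 3200 nM
compound 2, `C=C(C)CCC[C@]1(C)C2=CCC[C@](C)(C[C@H](O)C3=CC(=O)OC3O)[C@H]2CC[C@H]1C`, gives 3200 nM
compound 3, `C=C(C)CC[C@]1(C)C2=CCC[C@](C)(C[C@@H](OC(C)=O)C3=CC(=O)OC3O)[C@H]2CC[C@H]1C`, gives 11100 nM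

Compound 1 and compound 2 share one side chain but differ elsewhere; the difference between these two cores is not broken down here. Their numbers in this assay stand level at the digits given, so nothing separates them. Compound 3 carries the core of compound 1 with a shorter side chain, and the change, (1-methylethenyl in place of 2-methylprop-2-en-1-yl on a saturated chain carbon, two bonds along the chain from a saturated ring carbon), gave a 3.5-fold higher number from compound 1 to compound 3 (0.54 log units; beyond the scatter).

Compound 4, `C=C(C)CC[C@]1(C)C2=CCC[C@](C)(C[C@H](O)C3=CC(=O)OC3O)[C@H]2CC[C@H]1C`, has not yet been measured in this assay. It relates to compound 2 exactly as compound 3 relates to compound 1: the change is 1-methylethenyl in place of 2-methylprop-2-en-1-yl on a saturated chain carbon, two bonds along the chain from a saturated ring carbon, the same change at the same place. Among the measured compounds shown here, because compound 1 and compound 2 sit level at 3200 nM, and because the only measured instance of this change gave a 3.5-fold higher number from compound 1 to compound 3 (0.54 log units; beyond the scatter), the expectation is that the step is repeated on the second core, though one example is a thin basis and the outcome could differ. The expected step is therefore a 3.4-fold higher number from compound 2 to compound 4 (0.54 log units; beyond the scatter). For compound 4 in this assay the estimate is 11000 nM, with a plausible range from 4500 nM to 27000 nM.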

Compound 4, half-maximal inhibitory concentration: 4500 nM
The estimate for compound 4 lay 2.4-fold (0.39 log units) above the measured number; low and high end bracket the measured number.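

In this assay, putting 1-methylethenyl in place of 2-methylprop-2-en-1-yl on the second core gave a 1.4-fold higher number from compound 2 to compound 4 (0.15 log units; within the scatter), a step too small to tell apart from the ordinary variation between repeated measurements. Set beside the step on the first core, a 3.5-fold higher number from compound 1 to compound 3 (0.54 log units; beyond the scatter), it might look like a different result, yet the two steps themselves cannot be told apart: the same change on two cores in this assay, a 3.5-fold higher number (0.54 log units; beyond the scatter) from compound 1 to compound 3 and a 1.4-fold higher number (0.15 log units; within the scatter) from compound 2 to compound 4, 2.5-fold (0.39 log units) apart, within the scatter of two such steps. This fits the idea that the change carries from one core to the other, but it does not prove it, since only one of the two steps stands clear of the scatter, only two cores are shown, and neither the true size of the step nor the reason for it can be fixed from this pair.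

The compounds shown leave open how a longer chain, or a chain ending in an amine or a carboxylic acid, would behave on either core in this assay. They also leave open whether a third core would give a step nearer to the first or to the second.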